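The source may hold more compounds than are shown below. What is called first, only, known or untested is meant among the compounds shown, and "the series" means these compounds.

Compound 1 `Cc1cc(Nc2cc(-c3ccccc3)[nH]n2)n2nc(SCc3cccc(Br)c3)nc2n1` and compound 2 `Cc1cc(Nc2cc(-c3ccccc3)[nH]n2)n2nc(SCc3nc4ccccc4[nH]3)nc2n1` share one core and differ only in the group on a saturated chain carbon bound to a sulfur. In an ADME assay on GES1 cells (Homo sapiens) for inhibition, read by MTT assay, with a stated time of 72 h (a lower number here means a stronger inhibitor, a higher number a weaker inhibitor), compound 1 reaches only the assay limit of > 50000 nM. In this assay, going by the values given here, compound 2 gives 27800 nM, the sole outright number here. The step of an at least 1.7-fold lower number from compound 1 to compound 2 (0.25 log units; that floor lies within the scatter) rests on that limit of > 50000 nM in this assay, at which 1 of the 2 values shown sits, and cannot be sized. Compound 3 `Cc1cc(Nc2cc(-c3ccccc3)[nH]n2)n2nc(SCC3CC3)nc2n1` differs from compound 2 by cyclopropyl in place of 1H-benzimidazol-2-yl on a saturated chain carbon bound to a sulfur. Among the compounds with values here, no measured step covers this change. Compound 3 is therefore expected to shift by a 1.4-fold higher number from compound 2 to compound 3 (0.16 log units; within the scatter), toward weaker inhibition, with an estimated 40000 nM ranging from 15000 nM to 100000 nM.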

Compound 3, half-maximal inhibitory concentration: > 50000 nM
Compound 3: a limit, no number; the forecaster's own chance of this, stated with the estimate: 45%; middle value at least 1.2-fold (0.09 log units) from the limit.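

In this assay, as far as these compounds go, cyclopropyl in place of 1H-benzimidazol-2-yl gives an at least 1.7-fold higher number from compound 2 to compound 3 (0.25 log units; that floor lies within the scatter), a floor set by a limit, so the true size of this step stays unknown. Compound 3 stands at a limit, and the step between the 3-bromophenyl and cyclopropyl compounds cannot be read. Of the three groups on the saturated chain carbon bound to a sulfur, only 1H-benzimidazol-2-yl yields an outright number: the limit of > 50000 nM in this assay, at which 2 of the 3 values shown sit.

The compounds shown leave open where compound 1 and compound 3 truly lie. They also leave open whether an amine or a carboxylic acid at this place would give a number in this assay.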